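The compounds below may be only part of what the source reports. "The series", "measured", "known", "first", "only" and "open" are said of these compounds alone.

Compounds measured in a functional assay on CHO-K1 cells for antagonist activity at transient receptor potential cation channel subfamily V member 1 (Homo sapiens), read by FLIPR; on this read-out lower numbers stand for stronger inhibition and higher numbers for weaker inhibition:

Compound 1, `CCCCNc1nc(C(F)(F)F)ccc1CNC(=O)C(C)c1ccc(NS(C)(=O)=O)c(F)c1`: 293 nM
Compound 2, `Cc1ccc(Nc2nc(C(F)(F)F)ccc2CNC(=O)C(C)c2ccc(NS(C)(=O)=O)c(F)c2)cc1C`: 1160 nM
Compound 3, `CC(C(=O)NCc1ccc(C(F)(F)F)nc1N1CCC(C(=O)c2ccc(F)cc2)CC1)c1ccc(NS(C)(=O)=O)c(F)c1`: 990 nM

Compound 2 gives the highest of the three numbers in this assay. Within the data shown here, its nearest neighbour is compound 3, whose value of 990 nM lies within the scatter of that of compound 2; compound 1, at 293 nM, stands furthest away, and the one measured step, a 4.0-fold higher number from compound 1 to compound 2 (0.60 log units; beyond the scatter), shows that exchange beyond the scatter.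

Compound 4, `CC(C(=O)NCc1ccc(C(F)(F)F)nc1N1CCC(C(F)(F)F)CC1)c1ccc(NS(C)(=O)=O)c(F)c1`, has yet to be measured. Against compound 2 the change is 4-(trifluoromethyl)piperidin-1-yl in place of (3,4-dimethylphenyl)amino on an aromatic carbon. Among the measured compounds shown here, no measured step covers this exact exchange. The step of a 4.0-fold higher number from compound 1 to compound 2 (0.60 log units; beyond the scatter) shows that the substituent on the core next to the ring nitrogen can move the number by a modest amount, and compound 3, carrying a piperidin-1-yl group at that place, gives 990 nM. Compound 4 is therefore expected to land close to compounds 2 and 3, perhaps with a somewhat lower number, the step of a 1.9-fold lower number from compound 2 to compound 4 (0.29 log units; within the scatter) being the expectation. For compound 4 the estimate in this assay is 600 nM, within a range from 150 nM to 2400 nM.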

Compound 4, half-maximal inhibitory concentration: 31 nM
Beside the measured number, compound 4's estimate is 19-fold (1.29 log units) above it; the measured number lies below the stated range.
By their numbers in this assay, from the lowest: compound 4; then compound 1; then compounds 3 and 2 (each within the scatter of the next).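

The place next to the ring nitrogen on the shared core proves far more sensitive than the exchange of butyl for 3,4-dimethylphenyl had shown: in this assay, putting 4-(trifluoromethyl)piperidin-1-yl in place of (3,4-dimethylphenyl)amino gives a 37-fold lower number from compound 2 to compound 4 (1.57 log units; beyond the scatter) at this place. A piperidin-1-yl ring there does not alone bring the low number, as the substituent on its saturated ring carbon also counts, with trifluoromethyl in place of (4-fluorophenyl)carbonyl giving a 32-fold lower number from compound 3 to compound 4 (1.50 log units; beyond the scatter) in the same assay. The new group also improves on butylamino, with a 9.5-fold lower number from compound 1 to compound 4 (0.98 log units; beyond the scatter) and so compound 4 has the lowest number of the four compounds, its steps to all three others lying beyond the scatter.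

No accompanying measurement accounts for the size of these steps. Still open, from the compounds shown here alone, is what a methyl, a hydroxyl or a nitrile on the saturated ring carbon would give in place of trifluoromethyl, and whether a morpholine or pyrrolidine ring could stand in for the piperidin-1-yl ring at this place.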